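The source may report more compounds than this note shows. Statements on the series, on what has been measured and on what is new or still open speak of the compounds shown alone.

Measured in a functional assay on the whole organism for activation, with Mus musculus as the target; on this read-out lower numbers stand for an effect already at smaller amounts and higher numbers for an effect only at larger amounts of compound:
- compound 1 `CC(=O)C1(c2cc(F)cc(OCc3ccc(-n4ccnc4C)cc3)c2)CCOCC1`: 12 mg/kg
- compound 2 `Cc1nccn1-c1ccc(COc2cc(F)cc(C3(C(N)=O)CCOCC3)c2)cc1`: 4.9 mg/kg

Of these two, compound 2 has the lower number, 4.9 mg/kg. Compound 3 `COC1(c2cc(F)cc(OCc3ccc(-n4ccnc4C)cc3)c2)CCOCC1` has not yet been measured. It carries methoxy in place of carbamoyl on a saturated ring carbon.

Within the data shown here, only one measured step bears on this change: a 2.4-fold lower number from compound 1 to compound 2 (0.39 log units; beyond the scatter), with amino in place of methyl on a carbonyl carbon. That step keeps the carbonyl, whereas the new change removes it, so it offers only a rough guide to size and none to direction. In this assay, a step no larger than that modest one is expected, with a slight lean towards a higher number. The estimated step is a 1.4-fold higher number from compound 2 to compound 3 (0.15 log units; within the scatter). For compound 3 the estimate is 7 mg/kg, with an expected range of 2.5 mg/kg to 20 mg/kg.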

Compound 3, dose for half-maximal effect: 2 mg/kg
Beside the measured number, compound 3's estimate is 3.5-fold (0.54 log units) above it; the measured number lies below the stated range.
By their numbers in this assay, from the lowest: compound 3; then compound 2; then compound 1.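

In this assay, a carbonyl on this saturated ring carbon is not required: methoxy in place of carbamoyl gives a 2.5-fold lower number from compound 2 to compound 3 (0.39 log units; beyond the scatter) and methoxy in place of acetyl gives a 6.0-fold lower number from compound 1 to compound 3 (0.78 log units; beyond the scatter). Compound 1 and compound 2 both carry a carbonyl here, so they could only show a change on that carbonyl, whereas compound 3 shows that a group without one gives the lowest number of the three, with each step between them beyond the scatter. No measurement at hand accounts for this order.

The compounds shown do not separate the loss of the carbonyl from the size of the group or the change in hydrogen-bond donors. Nor do they show how a hydroxyl, a primary amine or a longer ether chain such as ethoxy would read at this carbon.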